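The compounds below may be only part of what the source reports. "The series", "measured", "known", "first", "only" and "open" are said of these compounds alone.

Working notes on the series. Compound 1 `Cc1cccc(C2CC(c3ccc(Cl)c(Cl)c3)=NN2C2=NC(=O)CS2)c1` gives 204000 nM in an ADME assay on RAW264.7 cells (Mus musculus) for cytotoxicity, read by MTT assay, with a stated time of 24 h; on this read-out higher numbers stand for lower toxicity in this test and lower numbers for higher toxicity in this test. Compound 2 `Cc1cccc(C2CC(c3ccc(C)c(C)c3)=NN2C2=NC(=O)CS2)c1` gives 237000 nM and compound 3 `Cc1ccc(C2=NN(C3=NC(=O)CS3)C(c3ccc(Br)cc3)C2)cc1C` gives 365000 nM; the three numbers lie at the low end with compound 1, yet a 1.2-fold higher number from compound 1 to compound 2 (0.07 log units; within the scatter) and a 1.5-fold higher number from compound 2 to compound 3 (0.19 log units; within the scatter) both stay within the scatter, and compound 1 against compound 3 is likewise within it. Compound 4 `Cc1ccc(C2CC(c3ccc(Cl)c(Cl)c3)=NN2C2=NC(=O)CS2)cc1` carries the change (4-methylphenyl in place of 3-methylphenyl on a saturated ring carbon). Within the data shown here, the only measured step at that same saturated ring carbon is a 1.5-fold higher number from compound 2 to compound 3 (0.19 log units; within the scatter), which is within the scatter, so the expected step of a 1.0-fold higher number from compound 1 to compound 4 (0.01 log units; within the scatter) is none beyond the scatter. Compound 4 is therefore estimated at 210000 nM, with a range from 100000 nM to 420000 nM.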

Compound 4, half-maximal cytotoxic concentration: 279000 nM
The estimate for compound 4 lay 1.3-fold (0.12 log units) below the measured number; measured number inside the range.
By their numbers in this assay, from the lowest: compounds 1, 2, 4 and 3 (each within the scatter of the next).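

Moving the methyl group, 4-methylphenyl in place of 3-methylphenyl on the saturated ring carbon, gives a 1.4-fold higher number from compound 1 to compound 4 (0.14 log units; within the scatter) in this assay with the 3,4-dichlorophenyl group held fixed. This is a second step at this carbon that stays within the scatter, so compound 1 and compound 4 cannot be told apart in this test. Nothing is available that would explain this result.

Still open, as far as these compounds go, is whether any change at this carbon moves the number beyond the scatter. An amine or a carboxylic acid on this phenyl ring, or a longer chain in place of the methyl, would test that.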